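Swapping methyl for chloro on the pendant phenyl ring

A few compounds are considered here, and "the series" means these few. Any claim that something is new, unique, unknown or untested is made for them only; others in the source may bear on it.

Measured compounds:
compound 1, `N#CC1=C(N)OC(c2c[nH]c3ccccc23)=C(C#N)C1c1ccc(Br)cc1`, 10.6%
compound 2, `CN(C)c1ccc(C2C(C#N)=C(N)OC(c3c[nH]c4ccccc34)=C2C#N)cc1`, 20.5%
compound 3, `Cc1ccccc1C1C(C#N)=C(N)OC(c2c[nH]c3ccccc23)=C1C#N`, 21.4%

In a functional assay, tested at 200 ug/mL (a higher number here means a stronger effect of the compound at the concentration tested, a lower number a weaker effect), compound 3 gives the highest of the three numbers. Its nearest neighbour is compound 2, and the step of a number 0.9 percentage points higher from compound 2 to compound 3 (within the scatter) lies within the scatter, so the two cannot be ordered. The step of a number 10.8 percentage points higher from compound 1 to compound 3 (beyond the scatter) is the only one beyond the scatter, and it comes from exchanging the whole aryl group on the saturated ring carbon.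

Compound 4, `N#CC1=C(N)OC(c2c[nH]c3ccccc23)=C(C#N)C1c1ccccc1Cl`, is not yet measured. It differs from compound 3 in one place:
chloro in place of methyl on an aromatic carbon

The steps that speak to this change are those that touch the pendant phenyl ring. The step of a number 9.9 percentage points higher from compound 1 to compound 2 (within the scatter), a substitution on an aromatic carbon of that ring, stays within the scatter, and so does a number 0.9 percentage points higher from compound 2 to compound 3 (within the scatter). Only a number 10.8 percentage points higher from compound 1 to compound 3 (beyond the scatter) is modest in size. A single-atom exchange of chloro for methyl is therefore expected to move this assay by no more than the scatter, in either direction.

Compound 4 is estimated to give 20%, within a range of 10% to 32%. The step of a number 1.4 percentage points lower from compound 3 to compound 4 (within the scatter) is expected to stay within the scatter.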

Compound 4, a percentage reported as activity, at one concentration (the size of the read-out at that concentration, not a potency): 14.5%
Estimate against measurement, compound 4: 5.5 percentage points above; the range from low to high includes it.
By their numbers in this assay, from the lowest: compounds 1, 4, 2 and 3 (each within the scatter of the next, the first and the last beyond it).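

In this assay, within the data shown here, the single-atom exchange on an aromatic carbon ortho to a large group gives a number 6.9 percentage points lower from compound 3 to compound 4 (within the scatter) and so shows directly, for the first time, that methyl and chloro at this place cannot be told apart. The step of a number 3.9 percentage points higher from compound 1 to compound 4 (within the scatter) and the step of a number 6 percentage points lower from compound 2 to compound 4 (within the scatter) leave compound 4 inseparable from the other two compounds, whereas the step of a number 10.8 percentage points higher from compound 1 to compound 3 (beyond the scatter) remains the only one in the set beyond the scatter; that separation from the 4-bromophenyl compound holds for 2-methylphenyl but is not matched by 2-chlorophenyl, even though compound 3 and compound 4 stand within the scatter of each other. Nothing available explains these numbers or says what either group does at this place.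

The compounds shown leave open whether a methoxy group, an amine or a carboxylic acid on this same aromatic carbon would reach beyond the scatter from compound 3. They also leave open whether methyl and chloro would remain indistinguishable on another carbon of the ring, or at another concentration in this assay as well.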